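This account rests on a few compounds, and the source may have more. Where it says the series, first, only, none or still open, it means among the compounds named here.

Measured so far in a functional assay with Homo sapiens as the target; on this read-out higher numbers stand for weaker inhibition and lower numbers for stronger inhibition:
- compound 1 `CC(C)[C@H](NC(=O)COc1cccc2ccccc12)C(=O)N[C@@H](CC(=O)O)C(=O)COc1ccccc1`: 11200 nM
- compound 2 `CC(C)[C@H](NC(=O)COc1cccc2ccccc12)C(=O)N[C@@H](CC(=O)O)C(=O)COc1ccccc1[N+](=O)[O-]`: 27700 nM
- compound 3 `CC(C)[C@H](NC(=O)COc1cccc2ccccc12)C(=O)N[C@@H](CC(=O)O)C(=O)COc1c(F)cccc1F`: > 100000 nM

Compound 3 stands at the weak end of this small set. Its entry of > 100000 nM is a limit of the assay and not a number.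

Compound 4 `CC(C)[C@H](NC(=O)COc1cccc2ccccc12)C(=O)N[C@@H](CC(=O)O)C(=O)COc1ccc(F)c(F)c1` keeps the rest of compound 3 and differs in one group: 3,4-difluorophenyl in place of 2,6-difluorophenyl on an oxygen on a saturated carbon. Here 3,4-difluorophenyl takes the place of 2,6-difluorophenyl on an oxygen on a saturated carbon, so the two compounds have the same atoms, joined differently.

Within the data shown here, three measured steps bear on this change. Nitro in place of hydrogen gave a 2.5-fold higher number from compound 1 to compound 2 (0.39 log units; beyond the scatter), a modest change. Replacing phenyl with 2,6-difluorophenyl gave an at least 8.9-fold higher number from compound 1 to compound 3 (0.95 log units; beyond the scatter), and replacing 2-nitrophenyl with 2,6-difluorophenyl gave an at least 3.6-fold higher number from compound 2 to compound 3 (0.55 log units; beyond the scatter). Among the measured compounds shown here, no measured compound carries the 3,4-difluorophenyl group, so the evidence is indirect.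

Compound 2, at 27700 nM, shows that a substituted phenyl can still give a number, so a return toward that region is expected for compound 4. In this assay the expected change is an at least 4.5-fold lower number from compound 3 to compound 4 (0.65 log units; beyond the scatter), toward stronger inhibition. The estimated value for compound 4 is 22000 nM, with an expected range from 7000 nM to 70000 nM.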

Compound 4, half-maximal inhibitory concentration: 16200 nM
The estimate for compound 4 lay 1.4-fold (0.13 log units) above the measured number; the measured number falls inside the stated range.
By their numbers in this assay, from the lowest: compounds 1, 4 and 2 (each within the scatter of the next, the first and the last beyond it). At a limit, above all of these: compound 3.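

In this assay, moving the two fluorines on the ring attached to the oxygen gave an at least 6.1-fold lower number from compound 3 to compound 4 (0.79 log units; beyond the scatter), so among these compounds the presence of fluorine alone does not bring the loss seen with compound 3; the arrangement in 2,6-difluorophenyl goes with that loss, while the same atoms as 3,4-difluorophenyl do not. The other two steps, a 1.7-fold lower number from compound 2 to compound 4 (0.23 log units; within the scatter) and a 1.4-fold higher number from compound 1 to compound 4 (0.16 log units; within the scatter), lie within the scatter, so 3,4-difluorophenyl cannot be told apart from 2-nitrophenyl or from phenyl at this position. The entry for compound 3 is a limit and not a number, so the first step gives only a bound on the size of the change: the limit of > 100000 nM in this assay, at which 1 of the 4 values shown sits.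

The compounds shown leave open whether a phenyl carrying one fluorine would behave like compound 3 or like compound 4. They also leave open whether a methoxy group or an amine on the phenyl ring would give a lower number than compound 1 does at 11200 nM in this assay.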